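The compounds below may be only part of what the source reports. "The series", "measured", "known", "first", "only" and "open" are said of these compounds alone.

Three compounds built on a shared core were tested in an ADME assay on HEK293 cells (Homo sapiens) for cytotoxicity, read by resazurin assay, with a stated time of 48 h; a lower number here means that less compound is tolerated, a higher number that more compound is tolerated. Compound 1 `O=S(=O)(Nc1ccc2oc(-c3ccccc3)nc2c1)c1cccc(C(F)(F)F)c1` gives only the limit of the assay, > 100000 nM, not a measured number. Compound 2 `O=S(=O)(Nc1ccc(-c2nc3ccccc3o2)cc1)c1ccc(Cl)s1` likewise gives only a limit, > 100000 nM. Compound 3 `C=Cc1ccc(S(=O)(=O)Nc2ccc3oc(-c4ccccc4)nc3c2)cc1` gives a measured value of 53000 nM. Compound 2 therefore stands at the limit of > 100000 nM in this assay, at which 2 of the 3 values shown sit. The unmeasured compound 4 `CCc1ccc(S(=O)(=O)Nc2ccc(-c3nc4ccccc4o3)cc2)cc1` differs from compound 2 in one place: 4-ethylphenyl in place of 5-chlorothiophen-2-yl on a sulfonyl sulfur. Among the compounds with values here, no step between two measured compounds is recorded here, so how much such a change moves the number is open; a shift no larger than the usual scatter is expected in this assay. Because compound 2 sits at the limit of > 100000 nM in this assay, at which 2 of the 3 values shown sit, compound 4 is expected to stay near that limit, estimated at 100000 nM within a range from 40000 nM to 250000 nM. That estimate means an expected step of a number no higher from compound 2 to compound 4 (the limit leaves the size open).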

Compound 4, half-maximal cytotoxic concentration: 82000 nM
For compound 4 the middle estimate is 1.2-fold (0.09 log units) above the measured one; the measured number falls inside the stated range.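

In this assay, 4-ethylphenyl in place of 5-chlorothiophen-2-yl on a sulfonyl sulfur gives an at least 1.2-fold lower number from compound 2 to compound 4 (0.08 log units; that floor lies within the scatter). This gives the position a first step, and compound 4 supplies a measured number where the chlorothiophene partner offers none. The real size of the step cannot be read, because compound 2 rests on a limit: the limit of > 100000 nM in this assay, at which 2 of the 4 values shown sit.

The compounds shown leave open how far the number moves with an amine or a carboxylic acid at this position. They also leave open whether a chain longer than ethyl would shift it beyond the scatter.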